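Fluorine on the Outer Ring of a Hydroxamic Acid Series

The compounds below may be only part of what the source reports. "The series", "measured", "known", "first", "only" and "open" are said of these compounds alone.

Compound 2 `O=C(NO)c1ccc(/C=C/c2ccnc(-c3ccccc3O)c2)cc1` and compound 1 `O=C(NO)c1ccc(/C=C/c2ccnc(-c3cc(F)ccc3O)c2)cc1` share a core and differ only where compound 1 carries fluoro in place of hydrogen on an aromatic carbon. In a functional assay on MGC-803 cells (Homo sapiens) for antiproliferative activity, read by CellTiter-Glo, with a stated time of 72 h (a higher number here means a weaker inhibitor, a lower number a stronger inhibitor), compound 2 gives 1420 nM, and compound 1 gives 1920 nM. That change made a 1.4-fold higher number from compound 2 to compound 1 (0.13 log units; within the scatter).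

Compound 3 `Cc1ccc(-c2cc(/C=C/c3ccc(C(=O)NO)cc3)c(F)cn2)cc1` has a different core; the difference between the two cores is not broken down here. In this assay compound 3 reaches only the limit of > 10000 nM, which is a bound of the assay and not a measured number, as the evidence the limit of > 10000 nM in this assay, at which 1 of the 3 values shown sits, shows. Compound 4 `Cc1ccc(-c2cc(/C=C/c3ccc(C(=O)NO)cc3)c(F)cn2)c(F)c1` is compound 3 with fluoro in place of hydrogen on an aromatic carbon. This is the same kind of change as from compound 2 to compound 1, but not the same: there the fluoro sat meta to a large group and para to a hydroxy group, here it sits ortho to a large group and meta to a methyl group.

Since the earlier step of this kind was within the scatter, the step from compound 3 to compound 4 in this assay is expected to be about a step that the limit leaves unreadable from compound 3 to compound 4. Compound 4 is therefore estimated to fall near 15000 nM, most likely again at the assay limit.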

Compound 4, half-maximal inhibitory concentration: 2510 nM
Estimate against measurement, compound 4: 6.0-fold (0.78 log units) above; the whole stated range lies above it.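

In this assay, fluoro in place of hydrogen on an aromatic carbon gave an at least 3.9-fold lower number from compound 3 to compound 4 (0.60 log units; beyond the scatter), and this step does not match the earlier one on the other core: the same change on two cores in this assay, a 1.4-fold higher number (0.13 log units; within the scatter) from compound 2 to compound 1 and an at least 3.9-fold lower number (0.60 log units; beyond the scatter) from compound 3 to compound 4, at least 5.3-fold (0.73 log units) apart, beyond the scatter of two such steps

The value of compound 3, > 10000 nM, is a limit of the assay and not a number, so this step has only a lower bound.

The result shows that the effect of this change cannot simply be carried from one core to another in this series, but it does not show whether the core or the place of the fluoro accounts for the gap, as the two cores carry it in different surroundings, and two steps establish no rule.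

The compounds shown leave open what the same 4-methylphenyl to 2-fluoro-4-methylphenyl change would do on the core of compound 2. Also open, going by these compounds, is whether a chlorine atom or a methoxy group in place of the fluoro would give a step of similar size from compound 3.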